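Losing the 4-methylphenyl group

This account rests on a few compounds, and the source may have more. Where it says the series, first, only, none or still open, it means among the compounds named here.

In a functional assay on CCRF-CEM cells (Homo sapiens) for inhibition, read by cell counting, with a stated time of 72 h (a higher number here means a weaker inhibitor, a lower number a stronger inhibitor), compound 1 (`CCN(CC)CN1C(=O)/C(=N/NC(=S)Nc2ccccc2)c2ccccc21`) gives 11000 nM and compound 2 (`CCN(CC)CN1C(=O)/C(=N/NC(=S)Nc2ccc(C)cc2)c2ccccc21`) gives 12000 nM, so compound 2 stands level with compound 1 within the scatter. Compound 3 (`CCN(CC)CN1C(=O)/C(=N/NC(N)=S)c2ccccc21`) carries hydrogen in place of 4-methylphenyl on an amide-type nitrogen. For the measured compounds named here, only one measured step bears on this, and a 1.1-fold higher number from compound 1 to compound 2 (0.04 log units; within the scatter) within the scatter concerns just a methyl on that aromatic ring, so it says little about removing the whole group. The step expected is a 2.1-fold higher number from compound 2 to compound 3 (0.32 log units; beyond the scatter), a modest move toward a higher number. For compound 3 the estimated value is 25000 nM, with a range of 8000 nM to 80000 nM.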

Compound 3, half-maximal inhibitory concentration: 164000 nM
Compound 3: the middle estimate sits 6.6-fold (0.82 log units) below what was measured; the measured number lies above the stated range.
By their numbers in this assay, from the lowest: compounds 1 and 2 (each within the scatter of the next); then compound 3.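

In this assay this amide-type nitrogen proves far less tolerant of change than the methyl step suggested: hydrogen in place of 4-methylphenyl gives a 14-fold higher number from compound 2 to compound 3 (1.14 log units; beyond the scatter), and hydrogen in place of phenyl gives a 15-fold higher number from compound 1 to compound 3 (1.17 log units; beyond the scatter). Among these compounds, having the aromatic ring on that nitrogen matters far more than having a methyl on it. Nothing available explains this difference.

Going by these compounds, whether an ethyl chain or a cyclohexyl ring on that nitrogen would keep the number near that of compound 1 remains open. So does the effect of a chlorine or a methoxy group on the phenyl ring.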